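The source may hold more compounds than are shown below. What is called first, only, known or untested is meant among the compounds shown, and "the series" means these compounds.

The compounds here share a thymidine-like core carrying an azide and a carbonate or carbamate side chain, and the question is how much each harms cultured cells. Compound 2 `Cc1cn(C2CC(N=[N+]=[N-])C(COC(=O)NCCCN)O2)c(=O)[nH]c1=O` is the starting point. In a functional assay on MT4 cells (Homo sapiens) for cytotoxicity (on this read-out higher numbers stand for lower toxicity in this test and lower numbers for higher toxicity in this test), compound 2 gives > 50000 nM, which is a limit of the test rather than a measured number. Its neighbour compound 1 `Cc1cn(C2CC(N=[N+]=[N-])C(COC(=O)OCCCCCCCCO)O2)c(=O)[nH]c1=O` carries a (8-hydroxyoctyl)oxy group where compound 2 carries (3-aminopropyl)amino on the carbonyl carbon. In this assay compound 1 gives > 50000 nM, again a limit. The step that the two limits leave unreadable from compound 1 to compound 2 therefore cannot be sized, because the limit of > 50000 nM in this assay, at which 2 of the 2 values shown sit, shows both values sitting at the same limit.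

Compound 3 `Cc1cn(C2CC(N=[N+]=[N-])C(COC(=O)OCCO)O2)c(=O)[nH]c1=O` is the next variation: 2-hydroxyethoxy in place of (3-aminopropyl)amino on a carbonyl carbon. Among the compounds with values here, no measured step bears directly on this exchange, and the one step available gives no readable size. With both known compounds at the limit, compound 3 is expected to show no step beyond the scatter, in other words a step that the limit leaves unreadable from compound 2 to compound 3 is expected to be close to nothing. Compound 3 is estimated at 100000 nM, in a range from 30000 nM to 400000 nM.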

Compound 3, half-maximal cytotoxic concentration: > 50000 nM
Compound 3 was reported as a limit (the forecaster's own chance of this, stated with the estimate: 85%); the middle value lies beyond the limit too.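

Within the data shown here, no step among compound 1, compound 2 and compound 3 can be read in this assay, because all three are reported only as a limit: the limit of > 50000 nM in this assay, at which 3 of the 3 values shown sit.

The compounds shown leave open whether any of these side chains on the shared core changes the harm to cells, and at what concentration each compound would begin to show it.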